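The compounds below may be only part of what the source reports. "The series", "measured", "known", "first", "only" and "open" are said of these compounds alone.

Working notes on the anilide series in an assay on microsomes from intestine for inhibition of acyl-CoA:cholesterol acyltransferase (Oryctolagus cuniculus); a higher number here means a weaker inhibitor, a lower number a stronger inhibitor.

Compound 1 `CCCCCCCC/C=C/CCCCCCCC(=O)Nc1ccccc1CC` gives 1200 nM in this assay. Within the data shown here, compound 2 `CCCCCCCC/C=C/CCCCCCCC(=O)Nc1ccccc1C(C)C`, which carries the change (methyl in place of hydrogen on a saturated chain carbon bound to an aromatic carbon and a saturated chain carbon), gives 600 nM in this assay; the step of a 2.0-fold lower number from compound 1 to compound 2 (0.30 log units; within the scatter) is the only single-point comparison among the measured compounds. Compound 3 `CCCCCCCCCCCCCCC(C)C(=O)Nc1c(OC)cc(OC)cc1OC` sits on a different core with a branched saturated chain and a trimethoxy-substituted ring; in this assay compound 3 gives 31 nM, the lowest of the three numbers, a step beyond the scatter from both compound 2 and compound 1. How the core of compound 3 differs from the core of compound 1 is not broken down here.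

Compound 4 `CCCCCCCCCCCCCCC(C)(C)C(=O)Nc1c(OC)cc(OC)cc1OC` is not yet measured. It differs from compound 3 by methyl in place of hydrogen on a saturated chain carbon bound to a carbonyl carbon and two saturated chain carbons. This is the same kind of change as from compound 1 to compound 2, but at a different place: there the carbon was bound to an aromatic carbon and a saturated chain carbon, here it is bound to a carbonyl carbon and two saturated chain carbons, so the two steps need not match.

Expectation: the only measured instance of this kind of change, a 2.0-fold lower number from compound 1 to compound 2 (0.30 log units; within the scatter), stayed within the scatter, so the step from compound 3 to compound 4 is expected to be small as well, a 1.0-fold lower number from compound 3 to compound 4 (0.01 log units; within the scatter), with wide uncertainty because the place differs and the core of compound 3 is only represented once. Compound 4 is estimated at 30 nM in this assay, between 8 nM and 110 nM.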

Compound 4, half-maximal inhibitory concentration: 44 nM
For compound 4 the middle estimate is 1.5-fold (0.17 log units) below the measured one, and the stated range covers the measured number.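

In this assay the methyl in place of hydrogen on a saturated chain carbon bound to a carbonyl carbon and two saturated chain carbons gives a 1.4-fold higher number from compound 3 to compound 4 (0.15 log units; within the scatter) and so leaves the number within the scatter on this core. The comparison rests on a single pair on each core, with the methyl at a different place in each pair, so it does not separate the influence of the core from that of the place and gives no general rule for the series. What it does show is that the step read on one core does not carry over to the other as a fixed size: the same change on two cores in this assay, a 2.0-fold lower number (0.30 log units; within the scatter) from compound 1 to compound 2 and a 1.4-fold higher number (0.15 log units; within the scatter) from compound 3 to compound 4, 2.8-fold (0.45 log units) apart, beyond the scatter of two such steps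

The compounds shown leave open how the methyl would behave at one and the same place on both the core of compound 1 and the core of compound 3, which is the comparison needed to tell core from place. Among these compounds, they also leave open what would follow in this assay if an ethyl group, an amine or a carboxylic acid stood on that same saturated chain carbon, or if a longer chain replaced the one carried by compound 4.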